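A few compounds are considered here, and "the series" means these few. Any claim that something is new, unique, unknown or untested is made for them only; others in the source may bear on it.

Series notes. Compound 1 `CC(C)(C)OC(=O)/C=C1/C(=O)Nc2ccccc21` in a functional assay on SAOS-2 cells (Homo sapiens) for inhibition, read by CCK-8 assay, with a stated time of 72 h, tested at 20 uM (a higher number here means more inhibition of growth at the concentration tested, a lower number less inhibition of growth), gives 83.3%, which places it between compound 3 `Cc1ccc2c(c1)/C(=C\C(=O)OC(C)(C)C)C(=O)N2` at 83.7% and compound 2 `CN1C(=O)/C(=C/C(=O)OC(C)(C)C)c2ccccc21` at 81.9%, all three within the scatter of one another. Two single changes to compound 1 have been measured: methyl in place of hydrogen on the amide-type ring nitrogen, a number 1.4 percentage points lower from compound 1 to compound 2 (within the scatter), and methyl in place of hydrogen on an aromatic carbon, a number 0.4 percentage points higher from compound 1 to compound 3 (within the scatter). Compound 4 `CC(C)(C)OC(=O)/C=C1/C(=O)Nc2ccc(OC(F)(F)F)cc21` differs from compound 1 by trifluoromethoxy in place of hydrogen on an aromatic carbon. Within the data shown here, only the step to compound 3 concerns an aromatic substitution, and it stayed within the scatter; a trifluoromethoxy group itself is untested. For compound 4 a step within the scatter is therefore expected, a number 2.3 percentage points lower from compound 1 to compound 4 (within the scatter). For compound 4 the estimated value in this assay is 81%, with a range of 68% to 90%.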

Compound 4, percent growth inhibition at one concentration: 80.1%
The estimate for compound 4 lay 0.9 percentage points above the measured number; low and high end bracket the measured number.
By their numbers in this assay, from the lowest: compounds 4, 2, 1 and 3 (each within the scatter of the next).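

In this assay, trifluoromethoxy, with its 5 heavy atoms, can stand on this aromatic carbon without a step beyond the scatter: a number 3.2 percentage points lower from compound 1 to compound 4 (within the scatter). Exchanging methyl for it at the same place gives the same reading, a number 3.6 percentage points lower from compound 3 to compound 4 (within the scatter), so hydrogen, methyl and trifluoromethoxy are not told apart here. No measurement available bears on why these groups read alike. Open, from the compounds shown here alone, is whether an amine, a carboxylic acid or a longer chain on this carbon would also stay within the scatter, and whether the three compounds would separate at other concentrations.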